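Methylsulfonyl for acetamido on an inactive antagonist series

The source may hold more compounds than are shown below. What is called first, only, known or untested is meant among the compounds shown, and "the series" means these compounds.

Compound 1 `CC(=O)Nc1cccc(OCc2cc(C)nc(-c3ccccn3)n2)c1`: > 39800 nM
Compound 2 `CC(=O)Nc1ccc(OCc2cc(C)nc(-c3ccccn3)n2)cc1`: > 39800 nM
Compound 3 `Cc1cc(COc2cccc(S(C)(=O)=O)c2)nc(-c2ccccn2)n1`: > 39800 nM

Three compounds were tested in a functional assay on cells for antagonist activity at Free fatty acid receptor 1 (Homo sapiens), read by TR-FRET and inositol phosphate accumulation, with a stated time of 2 h; on this read-out lower numbers stand for stronger inhibition and higher numbers for weaker inhibition. In this assay compound 1 gives > 39800 nM, which is a limit of the assay rather than a number. Compound 2 likewise returns > 39800 nM, again only a limit. Compound 3 also stays at > 39800 nM, a limit as well. All three therefore sit at the limit of > 39800 nM in this assay, at which 3 of the 3 values shown sit, and no ordering among them can be drawn.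

Compound 1 and compound 3 differ by one change, (methylsulfonyl in place of acetamido on an aromatic carbon). The step that the two limits leave unreadable from compound 1 to compound 3 cannot be read, since both ends are limits. Compound 2 is built from the same atoms as compound 1, joined differently; the difference between the two cores is not broken down here.

Compound 4 `Cc1cc(COc2ccc(S(C)(=O)=O)cc2)nc(-c2ccccn2)n1` has not yet been measured. It stands to compound 2 as compound 3 stands to compound 1: methylsulfonyl in place of acetamido on an aromatic carbon. The change is the same kind of change as before, but the place is not identical, being para to a large group in compound 4 where it was meta to a large group in compound 3. With every measured value resting at the limit, the step from compound 2 to compound 4 is expected to be about a step that the limit leaves unreadable from compound 2 to compound 4, because compound 2 gives only > 39800 nM. Compound 4 is accordingly estimated at 60000 nM, with a range from 20000 nM to 200000 nM, and most likely the assay will again report only a limit.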

Compound 4, half-maximal inhibitory concentration: > 39800 nM
Compound 4: only a limit was reported; the forecaster's own chance of this, stated with the estimate: 85%; the middle value does not contradict the limit.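

In this assay compound 4 gives > 39800 nM, again a limit and not a number. Compound 2 also gave only a limit, so the step between compound 2 and compound 4 cannot be read, and no new step emerges: the limit of > 39800 nM in this assay, at which 4 of the 4 values shown sit.

The compounds shown leave open how strongly any of the four inhibits the receptor, and whether methylsulfonyl in place of acetamido changes that inhibition at all.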